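The compounds below may be only part of what the source reports. "The series", "measured", "known", "first", "only" and "open" are said of these compounds alone.

Measured compounds in a functional assay on A549 cells (Homo sapiens) for antiproliferative activity, read by XTT assay, with a stated time of 24 h; a higher number here means a weaker inhibitor, a lower number a stronger inhibitor:
Compound 1, `Cc1ccc(C2=NN(c3nc(-c4ccc(Cl)cc4)cs3)C(c3ccc(F)cc3)C2)s1`, gives > 500 ug/mL, which is a limit of the assay and not a number.
Compound 2, `Fc1ccc(C2CC(c3ccc(Cl)s3)=NN2c2nc(-c3ccc(C(F)(F)F)cc3)cs2)cc1`, gives > 500 ug/mL, again a limit of the assay rather than a number.
Compound 3, `Fc1ccc(C2CC(c3ccc(Cl)s3)=NN2c2nc(-c3ccc(Cl)cc3)cs2)cc1`, gives 125 ug/mL.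

Compound 1 therefore stands at the top end of what this assay can report: its value is the limit of > 500 ug/mL in this assay, at which 2 of the 3 values shown sit. Only compound 3 has a true number, so the two steps that can be sized both run to it: an at least 4.0-fold lower number from compound 1 to compound 3 (0.60 log units; beyond the scatter) and an at least 4.0-fold lower number from compound 2 to compound 3 (0.60 log units; beyond the scatter). Each of these puts chloro in place of another group on an aromatic carbon, and each moves the number down by at least a modest amount.

The next compound, compound 4, is `Cc1ccc(C2=NN(c3nc(-c4ccc(Br)cc4)cs3)C(c3ccc(F)cc3)C2)s1`. Compared with compound 1 the change is bromo in place of chloro on an aromatic carbon. Going by the values given here, neither measured step exchanges one halogen for another, so no step bears directly on this change; both measured steps involve chloro entering, not leaving. Among the compounds with values here, with no matching precedent, and compound 1 sitting at a limit, the step of a number no higher from compound 1 to compound 4 (the limit leaves the size open) is expected to stay within the scatter, most likely leaving compound 4 at the limit as well. The estimated value for compound 4 in this assay is 500 ug/mL, with a range from 250 ug/mL to 1000 ug/mL.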

Compound 4, half-maximal inhibitory concentration: > 500 ug/mL
Compound 4: no number, only a limit (the forecaster's own chance of this, stated with the estimate: 70%); the middle value lies on the limit itself.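

Compound 4 gives > 500 ug/mL, which is a limit of the assay and not a number. Compound 1 is also held at a limit, so the step from compound 1 to compound 4 cannot be read: the limit of > 500 ug/mL in this assay, at which 3 of the 4 values shown sit. The compounds shown leave open whether 4-chlorophenyl or 4-bromophenyl gives the lower number on this shared core.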